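The source may report more compounds than this note shows. Statements on the series, on what has been measured and on what is new or still open speak of the compounds shown alone.

Measured compounds:
compound 1 `S=c1[nH]nc(-c2ccccc2Sc2ccccc2)o1` gives 13.1%
compound 2 `[O-][S+](c1ccccc1)c1ccccc1-c1n[nH]c(=S)o1` gives 40.9%
compound 3 `Nc1nnc(-c2ccccc2Sc2ccccc2)o1` gives 16.6%

These three compounds were tested in a functional assay on the whole organism (strain NMRI) for inhibition, with Mus musculus as the target, in the formalin test, with a stated time of 30 min, at a dose of 30 umol/kg by the intraperitoneal route; a higher number here means more inhibition at the dose given (going by the name of the read-out), a lower number less inhibition. In this assay compound 1 gives 13.1% and compound 3 gives 16.6%. The step between them, a number 3.5 percentage points higher from compound 1 to compound 3 (within the scatter), is the change (a group of 6 heavy atoms (2 carbon, 3 nitrogen, 1 oxygen; one five-membered aromatic ring with 3 hetero atoms) in place of a group of 6 heavy atoms (2 carbon, 2 nitrogen, 1 oxygen, 1 sulfur; one five-membered aromatic ring with 3 hetero atoms), on an aromatic carbon). Compound 2 stands apart from both: in this assay compound 2 gives 40.9%, and its margin over compound 3 and over compound 1 lies beyond the scatter. The difference between the core of compound 2 and the core of compound 1 is not broken down here.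

Compound 4 `Nc1nnc(-c2ccccc2[S+]([O-])c2ccccc2)o1` has not been measured. It differs from compound 2 by a group of 6 heavy atoms (2 carbon, 3 nitrogen, 1 oxygen; one five-membered aromatic ring with 3 hetero atoms) in place of a group of 6 heavy atoms (2 carbon, 2 nitrogen, 1 oxygen, 1 sulfur; one five-membered aromatic ring with 3 hetero atoms), on an aromatic carbon. This is the same kind of change as that from compound 1 to compound 3, though made on a different parent compound, as the two difference descriptions show.

Among the measured compounds shown here, the one measured instance of this change, a number 3.5 percentage points higher from compound 1 to compound 3 (within the scatter), stayed within the scatter, so the expected step for compound 4 is a number 3.1 percentage points higher from compound 2 to compound 4 (within the scatter), set beside that earlier step. Since this rests on a single pair, the expectation is loosely held. In this assay compound 4 is estimated to give 44%, expected to lie between 26% and 62%.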

Compound 4, a percentage reported as inhibition, in the whole organism at one dose (the size of the read-out at that dose, not a potency): 29.4%
Beside the measured number, compound 4's estimate is 14.6 percentage points above it; measured number inside the range.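

In this assay, putting 5-amino-1,3,4-oxadiazol-2-yl in place of the leaving group on the core of compound 2 gives a number 11.5 percentage points lower from compound 2 to compound 4 (beyond the scatter), so on this core the change costs inhibition, and the step is modest. The earlier pair had shown no step that could be told from the scatter, and the two results do not agree, so the outcome of this change did not carry over unaltered from one core to the other: the same change on two cores in this assay, a number 3.5 percentage points higher (within the scatter) from compound 1 to compound 3 and a number 11.5 percentage points lower (beyond the scatter) from compound 2 to compound 4, 15 percentage points apart, beyond the scatter of two such steps. Among the compounds shown here, this shows that, in this series, the result of the change depends on the core that carries it, but with only two pairs it gives no rule for any further core, and it does not show which feature of the two cores is responsible or how the step would look at another dose, since each number is a single-dose read-out and not a potency.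

The compounds shown leave open how a sulfone, with two oxygens on the sulfur, would behave under the same change. They also leave open whether a carboxylic acid or a longer alkylamine chain in place of the amino group would follow compound 2 or compound 4.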